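A few compounds are considered here, and "the series" means these few. Any claim that something is new, unique, unknown or untested is made for them only; others in the source may bear on it.

Measured so far in an ADME assay on HEp-2 cells (Homo sapiens) for cytotoxicity, read by MTT assay, with a stated time of 72 h; on this read-out lower numbers stand for stronger inhibition and higher numbers for weaker inhibition:

- compound 1 `COc1ccc(C2=C(c3cc(OC)c(OC)c(OC)c3)C(=O)C(OC(C)=O)C2)cc1F` gives < 1 ug/mL, a limit of the assay
- compound 2 `COc1ccc(C2=C(c3cc(OC)c(OC)c(OC)c3)C(=O)C(OC(C)=O)C2)cc1Cl` gives < 1 ug/mL, a limit of the assay
- compound 3 `COC(=O)c1cc(C2=C(c3cc(OC)c(OC)c(OC)c3)C(=O)CC2O[SiH2]C(C)(C)C)ccc1OC` gives > 100 ug/mL, a limit of the assay

Compound 2 stands at the lower limit of this assay: the limit of < 1 ug/mL in this assay, at which 2 of the 3 values shown sit. No number is known for it, only that its half-maximal inhibitory concentration lies at that limit. The other value shown is the limit of > 100 ug/mL in this assay, at which 1 of the 3 values shown sits, so the three measured compounds give no readable step at all.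

Among the measured compounds shown here, the one step that is measured, a step that the two limits leave unreadable from compound 1 to compound 2, runs between two limits and cannot be sized. Compound 3 differs from compound 2 in several places, so its value says nothing about any single change.

Compound 4 `COc1ccc(C2=C(c3cc(OC)c(OC)c(OC)c3)C(=O)C(OC(C)=O)C2)cc1O` differs from compound 2 in one place: hydroxy in place of chloro on an aromatic carbon. For the measured compounds named here, no measured step bears on this change. With nothing to go on beyond the two compounds at the lower limit, the working expectation is that compound 4 stays near that limit, with the step that the limit leaves unreadable from compound 2 to compound 4 expected to be small. Compound 4 is therefore estimated at 0.5 ug/mL, within 0.05 ug/mL to 3 ug/mL.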

Compound 4, half-maximal inhibitory concentration: > 100 ug/mL
Compound 4: no number, only a limit; the forecaster's own chance of this, stated with the estimate: 60%; at least 200-fold (2.30 log units) between middle value and limit.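

In this assay, the position ortho to a methoxy group on the aromatic ring proves highly sensitive to the group it carries: hydroxy in place of chloro gives an at least 100-fold higher number from compound 2 to compound 4 (2.00 log units; beyond the scatter), and hydroxy in place of fluoro gives an at least 100-fold higher number from compound 1 to compound 4 (2.00 log units; beyond the scatter). Among the compounds shown here, the earlier pair showed only that fluoro and chloro share one limit of the assay, whereas this change, with the rest of the structure held constant, gives the first readable step at this position and separates hydroxy from both halogens. Compound 4 stands at a limit of the assay, not at a number: the limit of > 100 ug/mL in this assay, at which 2 of the 4 values shown sit.

As far as these compounds go, the full size of either step stays open, as neither end of it is a number. Also open, from the compounds shown here alone, is whether an amine or a bromo group at this position would stay with the halogens or fall with hydroxy.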